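The source may hold more compounds than are shown below. What is called first, only, known or untested is meant among the compounds shown, and "the series" means these compounds.

Compound 1 `CN1CCN(c2nc3cc([N+](=O)[O-])ccc3o2)CC1` carries a nitro group on its core, and in an assay on ileum (strain Hartley) with 5-hydroxytryptamine receptor 3A (Cavia porcellus) as the target (a higher number here means a larger maximal response, a lower number a smaller maximal response), compound 1 gives 0.52. Compound 2 `Cc1cc(Cl)c2oc(N3CCN(C)CC3)nc2c1` gives 0.26, and compound 3 `Cc1cc(Cl)cc2nc(N3CCN(C)CC3)oc12` gives 0.24. Compound 1 therefore stands highest of the three, with both other values below it by more than the scatter, compound 2 the nearer and compound 3 the further. Within the data shown here, no two measured compounds differ in a single place, so no measured step exists. Compound 4 `COc1ccc2oc(N3CCN(C)CC3)nc2c1` is related to compound 1 by one change: methoxy in place of nitro on an aromatic carbon. Since compounds 2 and 3, which bear other groups on the core, sit below compound 1, a downward step beyond the scatter is expected. The estimate for compound 4 is 0.35, ranging from 0.15 to 0.6. That expected step is a number 0.17 lower from compound 1 to compound 4 (beyond the scatter).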

Compound 4, intrinsic activity: the largest response reached, as a fraction of the reference agonist's: 0.78
For compound 4 the middle estimate is 0.43 below the measured one; measured number above the stated range.
By their numbers in this assay, from the lowest: compounds 3 and 2 (each within the scatter of the next); then compound 1; then compound 4.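

Putting methoxy in place of nitro on this aromatic carbon changes the maximal response in this assay, with the step being a number 0.26 higher from compound 1 to compound 4 (beyond the scatter). Among these compounds, this is the first single-place comparison, and it shows that the group at this position alone can shift the response, with nitro giving the smaller value of this pair. No measurement shown here explains the step. As far as these compounds go, it remains open whether an amine or a hydroxyl on the same aromatic carbon would match methoxy or nitro. Nor do the compounds show whether the step would hold on the differently substituted cores of compound 2 and compound 3.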